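Norbornyl to Neopentyl on a Dipropylxanthine Core

A few compounds are considered here, and "the series" means these few. Any claim that something is new, unique, unknown or untested is made for them only; others in the source may bear on it.

Compound 3 `CCCn1c(=O)c2nc([C@@H]3CC4CCC3C4)[nH]c2n(CCC)c1=O` gives 3.8 nM in an assay on cell membranes for binding affinity to adenosine receptor A1 (Cavia porcellus), read by radioligand binding (on this read-out lower numbers stand for stronger inhibition and higher numbers for weaker inhibition), the lowest of the two numbers in this series. Compound 1 `CC1(Nc2ncnc3c2ncn3C2O[C@H](CO)[C@@H](O)[C@H]2O)CCCCC1`, which carries an adenine-type core rather than the xanthine core shared by the others, gives 70 nM in this assay, a gap that lies beyond the scatter. Compound 2 `CCCn1c(=O)c2nc(-c3cc4ccccc4s3)[nH]c2n(CCC)c1=O` reaches only a limit of the assay, > 100000 nM, which is not a number; this is the limit of > 100000 nM in this assay, at which 1 of the 3 values shown sits.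

Compound 4 `CCCn1c(=O)c2nc(CC(C)(C)C)[nH]c2n(CCC)c1=O` is compound 3 with the bridged bicyclic group replaced by a neopentyl group: a group of 5 heavy atoms (5 carbon; no ring) in place of a group of 7 heavy atoms (7 carbon; 2 five-membered non-aromatic rings of carbon only), on an aromatic carbon. Among the compounds with values here, no measured pair shows what such an exchange does. The two remaining compounds differ from compound 3 in more than one place, so they only show that the xanthine core with a bicyclic alkyl group gives the low number and that a different aromatic group at the same position does not.

Compound 4 is expected to bind more weakly than compound 3, with an estimated step of a 26-fold higher number from compound 3 to compound 4 (1.42 log units; beyond the scatter), since the ring-free group is smaller. The estimate for compound 4 is 100 nM, within a range from 15 nM to 800 nM.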

Compound 4, inhibition constant: 49 nM
Beside the measured number, compound 4's estimate is 2.0-fold (0.31 log units) above it; the measured number falls inside the stated range.
By their numbers in this assay, from the lowest: compound 3; then compounds 4 and 1 (each within the scatter of the next). At a limit, above all of these: compound 2.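

Neopentyl in place of the bridged bicyclic group is the first exchange on this aromatic carbon between two ring nitrogen atoms that can be read in this assay, and it brings a 13-fold higher number from compound 3 to compound 4 (1.11 log units; beyond the scatter). With no ring and no defined stereocentre in this group, compound 4 still gives 49 nM, so neither feature of the group in compound 3 is required for a measurable number at this position, although the exchange as a whole gives a large step. The data shown give no cause for this step.

The exchange alters the rings, the stereocentre and the heavy-atom count together, so what each contributes remains unresolved. From the compounds shown here alone, how a single cyclopentyl ring, a longer alkyl chain or an amine would fare at this position also remains open.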